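Acetyl for hydroxyl hydrogen in two cyclopentenone pairs

A few compounds are considered here, and "the series" means these few. Any claim that something is new, unique, unknown or untested is made for them only; others in the source may bear on it.

Measured so far:
Compound 1 `COc1cc(C2=C(c3cc(C)c(OC)c(C)c3)C(O)CC2=O)cc(OC)c1OC` in an ADME assay on KB cells (Homo sapiens) for cytotoxicity, read by MTT assay, with a stated time of 72 h (a lower number here means a stronger inhibitor, a higher number a weaker inhibitor), gives > 100 ug/mL, which is a limit of the assay and not a number.
Compound 2 `COc1cc(C2=C(c3cc(C)c(OC)c(C)c3)C(OC(C)=O)CC2=O)cc(OC)c1OC` in this assay gives > 100 ug/mL, again a limit and not a number.
Compound 3 `COc1ccc(C2=C(c3cc(OC)c(OC)c(OC)c3)C(=O)C(O)C2)cc1Cl` in this assay gives 2.5 ug/mL.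

Within the data shown here, compound 3 carries the only number in the set; the other two values are limits. The shared core of compound 1 and compound 3 is not the same, and the difference between the two cores is not broken down here.

The change from compound 1 to compound 2 is acetyl in place of hydrogen on an oxygen on a saturated carbon. Its step, a step that the two limits leave unreadable from compound 1 to compound 2, cannot be read, since both ends sit at the limit of > 100 ug/mL in this assay, at which 2 of the 3 values shown sit.

Compound 4 `COc1ccc(C2=C(c3cc(OC)c(OC)c(OC)c3)C(=O)C(OC(C)=O)C2)cc1Cl` is not yet measured. Its change from compound 3 is acetyl in place of hydrogen on an oxygen on a saturated carbon, the same change as from compound 1 to compound 2, at a place described in the same words. Because the earlier pair rests on (the limit of > 100 ug/mL in this assay, at which 2 of the 3 values shown sit), that pair says nothing about the size of the step to expect.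

With no readable step for this change, the expectation for compound 4 leans on the value of compound 3, 2.5 ug/mL, and allows a wide spread. Compound 4 is expected to give 4 ug/mL in this assay, with a range from 1.2 ug/mL to 15 ug/mL. This estimate means a step of a 1.6-fold higher number from compound 3 to compound 4 (0.20 log units; within the scatter), expected to fall within the usual scatter.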

Compound 4, half-maximal inhibitory concentration: 64 ug/mL
For compound 4 the middle estimate is 16-fold (1.20 log units) below the measured one; measured number above the stated range.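

In this assay, acetyl in place of hydrogen on an oxygen on a saturated carbon gives a 26-fold higher number from compound 3 to compound 4 (1.41 log units; beyond the scatter), so on the core of compound 3 the hydroxy to acetoxy change is a large step towards a weaker inhibitor. The same change on the core of compound 1 cannot be read, because compound 1 and compound 2 both sit at a limit of the assay and not at a number: the limit of > 100 ug/mL in this assay, at which 2 of the 4 values shown sit. The series therefore holds one readable step for this change, on one core, and it shows neither that the step carries over to the other core nor that it fails to do so; the two cores also differ in more than one place, so compound 1 and compound 3 cannot be compared directly.

The compounds shown leave open whether the large step belongs to the acetyl group itself or would also appear with a longer acyl chain such as butyryl on the same oxygen. They also leave open how the core of compound 3 would respond if an amine or a carboxylic acid stood at that saturated carbon in place of the hydroxy group.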